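Urea aryl variation on the shared core, 3,4-dichlorophenyl to 3-(trifluoromethyl)phenyl

The source may hold more compounds than are shown below. What is called first, only, known or untested is meant among the compounds shown, and "the series" means these compounds.

Three compounds of the series have numbers in a functional assay on SN12C cells (Homo sapiens) for inhibition, read by sulforhodamine B assay, with a stated time of 48 h, tested at 1 uM; on this read-out higher numbers stand for a weaker effect at the one concentration tested and lower numbers for a stronger effect. Compound 1 `COc1cc(Cl)cc(-c2nn(-c3cccc(NC(=O)Nc4ccc(Cl)c(C(F)(F)F)c4)c3)cc2-c2ccncc2)c1` gives 63%, compound 2 `COc1cc(Cl)cc(-c2nn(-c3cccc(NC(=O)Nc4cc(C(F)(F)F)cc(C(F)(F)F)c4)c3)cc2-c2ccncc2)c1` gives 17%, and compound 3 `COc1cc(Cl)cc(-c2nn(-c3cccc(NC(=O)Nc4ccc(Cl)c(Cl)c4)c3)cc2-c2ccncc2)c1` gives 87%. Compound 3 thus stands highest of the three, with compound 1 nearest and compound 2 furthest away, both gaps beyond the scatter. Going by the values given here, the one measured single step runs a number 24 percentage points higher from compound 1 to compound 3 (beyond the scatter).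

Compound 4 `COc1cc(Cl)cc(-c2nn(-c3cccc(NC(=O)Nc4cccc(C(F)(F)F)c4)c3)cc2-c2ccncc2)c1` is not yet measured. It differs from compound 3 by 3-(trifluoromethyl)phenyl in place of 3,4-dichlorophenyl on an amide-type nitrogen. The measured step from compound 1 to compound 3 bears on this, read in reverse: trifluoromethyl in place of chloro lowered the number by a modest amount. The present change is not that same exchange alone, since the entering 3-(trifluoromethyl)phenyl carries no chlorine, so the outcome is less certain; compound 2, with two trifluoromethyl groups, sits far lower still. A modest downward step in this assay is expected, a number 17 percentage points lower from compound 3 to compound 4 (beyond the scatter). Compound 4 is therefore estimated at 70%, within 45% to 95%.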

Compound 4, a percentage reported as activity, at one concentration (the size of the read-out at that concentration, not a potency): 59%
Beside the measured number, compound 4's estimate is 11 percentage points above it; the range from low to high includes it.
By their numbers in this assay, from the lowest: compound 2; then compounds 4 and 1 (each within the scatter of the next); then compound 3.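

In this assay, the step to 3-(trifluoromethyl)phenyl on the amide-type nitrogen gives a number 28 percentage points lower from compound 3 to compound 4 (beyond the scatter), while hydrogen in place of chloro gives a number 4 percentage points lower from compound 1 to compound 4 (within the scatter), so on the trifluoromethyl-bearing aryl this chloro exchange does not separate the two compounds. Hydrogen in place of trifluoromethyl gives a number 42 percentage points higher from compound 2 to compound 4 (beyond the scatter), the largest of the new steps, which makes the second trifluoromethyl group a far more telling exchange on this aryl than the chloro. Nothing at hand gives a reason for these steps.

Still open, as far as these compounds go, is whether the second trifluoromethyl group can be matched by a nitrile, a methoxy or a dimethylamino group at the same place on the aryl. A read-out at one concentration shows only a stronger or weaker effect of these ureas at that concentration.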